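Moving the methyl on the amide-linked phenyl ring

The source may hold more compounds than are shown below. What is called first, only, known or untested is meant among the compounds shown, and "the series" means these compounds.

Measured compounds:
compound 1, `CNC(=O)c1cc(-c2ccc(F)cc2F)ccc1OC(C)=O`, 29.9%
compound 2, `CC(=O)Oc1ccc(-c2ccc(F)cc2F)cc1C(=O)Nc1ccccc1C`, 12.3%

The study runs on a functional assay on the whole organism (strain Kunming) for inhibition, with Mus musculus as the target, in the writhing test, at a dose of 40 mg/kg by the oral route; on this read-out lower numbers stand for less inhibition and higher numbers for more inhibition at the one dose given (going by the name of the read-out). Compound 1 gives 29.9%. Compound 2 gives 12.3%, which is the lowest of the two numbers; its nearest neighbour is compound 1, with a step of a number 17.6 percentage points lower from compound 1 to compound 2 (beyond the scatter) between them.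

Compound 3, `CC(=O)Oc1ccc(-c2ccc(F)cc2F)cc1C(=O)Nc1ccc(C)cc1`, is not yet measured. It differs from compound 2 in one place: 4-methylphenyl in place of 2-methylphenyl on an amide-type nitrogen.

Among the compounds with values here, the only measured step, a number 17.6 percentage points lower from compound 1 to compound 2 (beyond the scatter), exchanged a methyl for a 2-methylphenyl on the amide-type nitrogen, so it is a different kind of change and says nothing directly about moving the methyl from one ring position to another. Within the data shown here, with no measured step bearing on this exchange, a step of a number 2.7 percentage points higher from compound 2 to compound 3 (within the scatter) is expected, within the scatter either way. Compound 3 is therefore estimated at 15%, with a range from 3% to 30%.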

Compound 3, a percentage reported as inhibition, in the whole organism at one dose (the size of the read-out at that dose, not a potency): 31%
For compound 3 the middle estimate is 16 percentage points below the measured one; the whole stated range lies below it.
By their numbers in this assay, from the lowest: compound 2; then compounds 1 and 3 (each within the scatter of the next).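

In this assay, 4-methylphenyl in place of 2-methylphenyl on the amide-type nitrogen gives a number 18.7 percentage points higher from compound 2 to compound 3 (beyond the scatter), so with the same atoms joined differently, where the methyl sits on this ring clearly changes the read-out. Against the small methyl on that nitrogen, the 4-methylphenyl gives a number 1.1 percentage points higher from compound 1 to compound 3 (within the scatter), which shows that a methyl-bearing phenyl ring at this place does not by itself go with a low number; of the three compounds, only compound 2 stands apart. No measurement at hand accounts for the gap between the two methylphenyl groups.

The compounds shown leave open how a 3-methylphenyl would read at this nitrogen. They also leave open whether a chlorine or a methoxy group in place of the methyl of the 4-methylphenyl would keep the number of compound 3.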